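Swapping the halogenated ring on the terminal amide

The source may report more compounds than this note shows. Statements on the series, on what has been measured and on what is new or still open speak of the compounds shown alone.

Compound 3, with the structure `Cc1ccc(S(=O)(=O)N[C@@H](CC(=O)NC(C)(C)C)C(=O)NCCNC(=O)c2ccccc2F)cc1`, was tested in an ADME assay on HepG2 cells (Homo sapiens) for cytotoxicity; on this read-out lower numbers stand for an effect already at smaller amounts and higher numbers for an effect only at larger amounts of compound. In this assay compound 3 gives only a limit, > 11000 nM, and no number. Two close relatives share its core and differ only in the ring carried on the carbonyl carbon of the terminal amide. Compound 1, `Cc1ccc(S(=O)(=O)N[C@@H](CC(=O)NC(C)(C)C)C(=O)NCCNC(=O)c2cc(Cl)ccn2)cc1`, reaches only the limit > 11000 nM in this assay. Compound 2, `COc1cccc(C(=O)NCCNC(=O)[C@H](CC(=O)NC(C)(C)C)NS(=O)(=O)c2ccc(C)cc2)c1`, likewise reaches only the limit > 11000 nM. The steps a step that the two limits leave unreadable from compound 1 to compound 2, a step that the two limits leave unreadable from compound 1 to compound 3 and a step that the two limits leave unreadable from compound 2 to compound 3 therefore cannot be sized, because the limit of > 11000 nM in this assay, at which 3 of the 3 values shown sit, and nothing else has been seen. Compound 4, `Cc1ccc(S(=O)(=O)N[C@@H](CC(=O)NC(C)(C)C)C(=O)NCCNC(=O)c2ccc(Cl)cc2)cc1`, has not yet been measured in this assay. Its difference from compound 3 is 4-chlorophenyl in place of 2-fluorophenyl on a carbonyl carbon. The three measured steps all exchange one ring on the same carbonyl carbon and none produced a readable cytotoxic effect, so the expected change a step that the limit leaves unreadable from compound 3 to compound 4 is none beyond the scatter, with the result most likely again a limit. Compound 4 is accordingly estimated at 20000 nM, within the range 8000 nM to 60000 nM.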

Compound 4, half-maximal effective concentration: > 11000 nM
Compound 4: no number, only a limit; the forecaster's own chance of this, stated with the estimate: 85%; the middle value lies beyond the limit too.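

Compound 4 gives only a limit in this assay, so its steps from compound 1, compound 2 and compound 3 cannot be read, and none of the ring exchanges can be sized: the limit of > 11000 nM in this assay, at which 4 of the 4 values shown sit.

The compounds shown leave open at what concentration any of them would show an effect in this assay, and whether the ring on the carbonyl carbon changes that concentration.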